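From 2-chlorobenzyl to 2-bromobenzyl

The source may hold more compounds than are shown below. What is called first, only, known or untested is meant among the compounds shown, and "the series" means these compounds.

In a functional assay on HUVEC cells (Homo sapiens) for antiproliferative activity, read by MTT assay, with a stated time of 24 h (on this read-out higher numbers stand for weaker inhibition and lower numbers for stronger inhibition), compound 1 `COc1cc(OC)c(-c2coc3cc(OCC=C(C)C)ccc3c2=O)cc1OC` gives 3800 nM, and compound 2 `COc1cc(OC)c(-c2coc3cc(OCc4ccccc4)ccc3c2=O)cc1OC` gives 9750 nM. Compound 3 `COc1cc(OC)c(-c2coc3cc(OCc4ccccc4Cl)ccc3c2=O)cc1OC` gives only a limit, > 10000 nM. Compound 4 `COc1cc(OC)c(-c2coc3cc(OCc4ccccc4Br)ccc3c2=O)cc1OC` carries bromo in place of chloro on an aromatic carbon, ortho to a large group: bromo in place of chloro on an aromatic carbon. The closest measured change is chloro in place of hydrogen, an at least 1.0-fold higher number from compound 2 to compound 3 (0.01 log units; that floor lies within the scatter), whose floor lies within the scatter. The larger steps, a 2.6-fold higher number from compound 1 to compound 2 (0.41 log units; beyond the scatter) and an at least 2.6-fold higher number from compound 1 to compound 3 (0.42 log units; beyond the scatter), exchange the whole 2-methylprop-1-en-1-yl group and bear on this change less directly. No step beyond the scatter is therefore expected in this assay. The expected step is a step that the limit leaves unreadable from compound 3 to compound 4. The estimate for compound 4 is 11000 nM, with an expected range of 6000 nM to 25000 nM.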

Compound 4, half-maximal inhibitory concentration: > 10000 nM
Compound 4 gave a limit, no number; the forecaster's own chance of this, stated with the estimate: 60%; the middle value is on the limit's open side.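

In this assay, the exchange of chloro for bromo on this aromatic carbon, ortho to a large group, cannot be read, since compound 3 and compound 4 both end in a limit: the limit of > 10000 nM in this assay, at which 2 of the 4 values shown sit.

Bromo in place of hydrogen gives an at least 1.0-fold higher number from compound 2 to compound 4 (0.01 log units; that floor lies within the scatter), so no change at this carbon is established for either halogen. Against the 2-methylprop-1-en-1-yl end of the chain, the 2-bromophenyl group gives an at least 2.6-fold higher number from compound 1 to compound 4 (0.42 log units; beyond the scatter), matching what the 2-chlorophenyl group showed.

On these data alone, how far compound 3 and compound 4 lie past the limit stays open. So does the effect of an amine or a carboxylic acid at this aromatic carbon.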